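This account rests on a few compounds, and the source may have more. Where it says the series, first, only, none or still open, it means among the compounds named here.

Measured compounds in a functional assay on MDA-MB-231 cells (Homo sapiens) for antiproliferative activity, read by MTT assay, with a stated time of 72 h; a lower number here means a stronger inhibitor, a higher number a weaker inhibitor:
- compound 1 `CC(=O)O[C@H]1CC[C@]2(C)[C@H](CC[C@@](C)(O)[C@H]2CC[C@@H]2C(C)=CC[C@H]3[C@H](CC[C@]3(C)OC(C)=O)C2(C)C)OC1(C)C` gives 26200 nM
- compound 2 `CC1=CC[C@H]2[C@H](CC[C@]2(C)O)C(C)(C)[C@@H]1CC[C@H]1[C@]2(C)CC[C@H](OC(=O)CCC(=O)O)C(C)(C)O[C@H]2CC[C@@]1(C)O` gives 27900 nM
- compound 3 `CC1=CC[C@H]2[C@H](CC[C@]2(C)O)C(C)(C)[C@@H]1CC[C@H]1[C@]2(C)CC/C(=N/O)C(C)(C)O[C@H]2CC[C@@]1(C)O` gives 42700 nM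

All three numbers sit close together. Compound 2 has the second highest of the three values; the gap to compound 1 and the gap to compound 3 both lie within the usual scatter, so nothing in these figures separates compound 2 from either of its neighbours, and none of the three can be called stronger or weaker than the others.

Compound 4 `CC1=CC[C@H]2[C@H](CC[C@]2(C)O)C(C)(C)[C@@H]1CC[C@H]1[C@]2(C)CC[C@H](OC(=O)c3ccc([N+](=O)[O-])cc3)C(C)(C)O[C@H]2CC[C@@]1(C)O` is not yet measured. It differs from compound 2 in one place:

4-nitrophenyl in place of 2-carboxyethyl on a carbonyl carbon

Going by the values given here, no pair of measured compounds differs in just one place, so there is no measured step to lean on. Given that the three measured compounds, with quite different groups on the shared core, all fall in the same narrow band, the working expectation for a 1.4-fold lower number from compound 2 to compound 4 (0.14 log units; within the scatter) is a step no larger than the scatter, with at most a slight move toward a lower number. Compound 4 is therefore estimated at 20000 nM, with a range from 8000 nM to 50000 nM.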

Compound 4, half-maximal inhibitory concentration: 8900 nM
The estimate for compound 4 lay 2.2-fold (0.35 log units) above the measured number; the range from low to high includes it.
By their numbers in this assay, from the lowest: compound 4; then compounds 1, 2 and 3 (each within the scatter of the next).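

In this assay, this acyl position on the shared core responds to a change of group: 4-nitrophenyl in place of 2-carboxyethyl on a carbonyl carbon gives a 3.1-fold lower number from compound 2 to compound 4 (0.50 log units; beyond the scatter), a modest step but one beyond the scatter. Going by these compounds alone, this single-place comparison shows that the group on this carbonyl carbon can shift the antiproliferative read-out, which the earlier compounds, differing in more than one place, could not show. The change replaces an open chain bearing a hydrogen-bond donor with a six-membered aromatic ring bearing none, and no measurement here accounts for the step.

Going by these compounds, it remains open whether the aromatic ring alone or the nitro group accompanies the lower number; unsubstituted phenyl or 4-methoxyphenyl on the same carbonyl carbon would separate the two. Also open, on these data alone, is whether the ester linkage matters, which an amide at this position would test.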